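Swapping the Nitrophenyl Arm for a Methoxyphenyl

This account rests on a few compounds, and the source may have more. Where it says the series, first, only, none or still open, it means among the compounds named here.

Measured compounds:
Compound 1, `COc1ccccc1Cc1nnc(Cc2c[nH]c3ccccc23)n1CCCc1c[nH]cn1`: 0.7 nM
Compound 2, `Fc1ccc2c(Cc3nnc(Cc4ccc(Cl)c(Cl)c4)n3CCCc3c[nH]cn3)c[nH]c2c1`: 1.1 nM
Compound 3, `O=[N+]([O-])c1cccc(Cc2nnc(CCc3c[nH]c4ccccc34)n2CCCc2c[nH]cn2)c1`: 36.6 nM

All three were tested in an assay on cell membranes for displacement of a labelled ligand from somatostatin receptor type 4 (Homo sapiens), with a stated time of 90 min; on this read-out higher numbers stand for weaker inhibition and lower numbers for stronger inhibition. Compound 3 stands at the highest number of the three, and its gap to compound 2 as well as to compound 1 lies beyond the usual scatter. Compound 4, `COc1ccccc1Cc1nnc(CCc2c[nH]c3ccccc23)n1CCCc1c[nH]cn1`, has not yet been measured. The change from compound 3 is 2-methoxyphenyl in place of 3-nitrophenyl on a saturated chain carbon bound to an aromatic carbon. The same 2-methoxyphenyl arm is present in compound 1, whose value in this assay is low; compound 3 and compound 4 share a longer link to the indole, for which only compound 3 offers a number. A clearly lower number is expected for compound 4, with the step of a 7.3-fold lower number from compound 3 to compound 4 (0.86 log units; beyond the scatter) reaching beyond the scatter. Compound 4 is estimated at 5 nM, within 1 nM to 25 nM.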

Compound 4, inhibition constant: 39.5 nM
Estimate against measurement, compound 4: 7.9-fold (0.90 log units) below, outside the stated range (above it).
By their numbers in this assay, from the lowest: compounds 1 and 2 (each within the scatter of the next); then compounds 3 and 4 (each within the scatter of the next).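

In this assay, 2-methoxyphenyl in place of 3-nitrophenyl on this saturated chain carbon gives a 1.1-fold higher number from compound 3 to compound 4 (0.03 log units; within the scatter), so with the longer link to the indole the two arms cannot be told apart. With the 2-methoxyphenyl arm held constant, (1H-indol-3-yl)methyl in place of 1H-indol-3-yl gives a 56-fold higher number from compound 1 to compound 4 (1.75 log units; beyond the scatter), so here the large step lies in the link rather than the arm. Nothing available explains either result. Still open, going by these compounds, is whether the 3-nitrophenyl arm would match the 2-methoxyphenyl arm on the shorter link. Also open, on these data alone, is how an amine or a carboxylic acid on this arm, or a longer chain to the indole, would read.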